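The source may report more compounds than this note shows. Statements on the series, on what has been measured and on what is new or still open speak of the compounds shown alone.

Compound 1 `CC(C)CCn1c(Cn2c(=O)n(C(C)C)c3ccccc32)nc2cc(C(C)(C)N)ccc21` gives 3270 nM in an ADME assay on HEp-2 cells (Homo sapiens) for cytotoxicity (on this read-out higher numbers stand for lower toxicity in this test and lower numbers for higher toxicity in this test), the lowest of the two numbers recorded. Compound 2 `CC(C)CCn1c(Cn2c(=O)n(C(C)C)c3ccccc32)nc2cccc(CN)c21` gives 11000 nM in this assay, a gap that lies beyond the scatter. Compound 3 `CC(C)CCn1c(Cn2c(=O)n(C(C)C)c3ccccc32)nc2cc(N)ccc21` is not yet measured and differs from compound 1 as follows: amino in place of 1-amino-1-methylethyl on an aromatic carbon. For the measured compounds named here, no comparable step between measured compounds exists, so the expected step from compound 1 to compound 3 in this assay is a small rise, a 1.5-fold higher number from compound 1 to compound 3 (0.18 log units; within the scatter), possibly within the scatter. Compound 3 is therefore estimated at 5000 nM, in a range from 1500 nM to 16000 nM.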

Compound 3, half-maximal cytotoxic concentration: 32200 nM
For compound 3 the middle estimate is 6.4-fold (0.81 log units) below the measured one; the measured number lies above the stated range.
By their numbers in this assay, from the lowest: compound 1; then compound 2; then compound 3.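

In this assay, the aromatic carbon meta to a fused ring and para to a fused ring responds strongly to this exchange: the change gives a 9.8-fold higher number from compound 1 to compound 3 (0.99 log units; beyond the scatter), and the number moves towards lower toxicity in this test. The leaving and entering groups carry equal counts of hydrogen-bond donors and acceptors, so those counts do not track the step. The compounds shown leave open how a methyl, a hydroxyl or an aminoethyl chain at this carbon would read. Nothing measured here accounts for the step.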